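The source may hold more compounds than are shown below. What is called first, only, known or untested is meant among the compounds shown, and "the series" means these compounds.

Compound 1 `Cc1ccc(F)cc1NC(=O)CN1CCN(c2nnc(Cc3ccccc3)c3ccccc23)CC1` sits at the weak end of the three measured compounds: in a functional assay on HT-29 cells (Homo sapiens) for cytotoxicity, read by MTT assay, with a stated time of 72 h (a higher number here means a weaker inhibitor, a lower number a stronger inhibitor), compound 1 gives 171000 nM, whereas compound 3 `Cc1ccccc1NC(=O)CN1CCN(c2nnc(Cc3ccncc3)c3ccccc23)CC1` gives 15000 nM and compound 2 `O=C(CN1CCN(c2nnc(Cc3ccncc3)c3ccccc23)CC1)Nc1cccc(Br)c1` gives 1350 nM. Compound 4 `O=C(CN1CCN(c2nnc(Cc3ccccc3)c3ccccc23)CC1)Nc1c(F)cccc1F` differs from compound 1 only at the amide-type nitrogen: 2,6-difluorophenyl in place of 5-fluoro-2-methylphenyl on an amide-type nitrogen. Among the compounds with values here, the one measured step that touches the same place, a change of the aryl group on that nitrogen, is an 11-fold higher number from compound 2 to compound 3 (1.05 log units; beyond the scatter), which shows that this position can move the read-out a long way in either direction. Within the data shown here, no step tells which way a 2,6-difluorophenyl group would move it, so the expectation for compound 4 is broad and centred near compound 1, at 100000 nM with a range from 20000 nM to 400000 nM; the expected step is a 1.7-fold lower number from compound 1 to compound 4 (0.23 log units; within the scatter).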

Compound 4, half-maximal inhibitory concentration: 19700 nM
The estimate for compound 4 lay 5.1-fold (0.71 log units) above the measured number; the measured number lies below the stated range.
By their numbers in this assay, from the lowest: compound 2; then compounds 3 and 4 (each within the scatter of the next); then compound 1.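

In this assay, 2,6-difluorophenyl in place of 5-fluoro-2-methylphenyl on the amide-type nitrogen gives an 8.7-fold lower number from compound 1 to compound 4 (0.94 log units; beyond the scatter). Within the data shown here, the only earlier step at this position was on the core of compound 2, so this shows that the aryl group also moves the read-out on the core of compound 1, even with the heavy-atom count unchanged. No measured evidence explains the step.

The compounds shown do not separate the loss of the methyl group from the change in fluorine substitution. They also leave open how an amine or a carboxylic acid on that aryl ring would move the number.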